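This account rests on a few compounds, and the source may have more. Where it says the series, first, only, none or still open, it means among the compounds named here.

Of the compounds shown here, three sharing one core have been tested in a functional assay on MGC-803 cells (Homo sapiens) for inhibition, read by MTT assay, with a stated time of 72 h; on this read-out lower numbers stand for stronger inhibition and higher numbers for weaker inhibition. Compound 1 `CCc1cccc(NC(=O)CSc2nc(Nc3ccccc3)c3ccccc3n2)c1` gives 15800 nM. Compound 2 `COc1cccc(NC(=O)CSc2nc(Nc3ccccc3)c3ccccc3n2)c1` gives 10000 nM. Compound 3 `O=C(CSc1nc(Nc2ccccc2)c2ccccc2n1)Nc1ccc(Cl)cc1` gives 40400 nM, the highest of the three numbers: the steps of a 2.6-fold higher number from compound 1 to compound 3 (0.41 log units; beyond the scatter) and a 4.0-fold higher number from compound 2 to compound 3 (0.61 log units; beyond the scatter) are both modest and beyond the scatter, whereas a 1.6-fold lower number from compound 1 to compound 2 (0.20 log units; within the scatter) stays within it. Compound 4 `O=C(CSc1nc(Nc2ccccc2)c2ccccc2n1)Nc1ccc([N+](=O)[O-])cc1` differs from compound 3 by nitro in place of chloro on an aromatic carbon. Going by the values given here, no measured step exchanges one group for another on that aryl; the two steps that replace the whole aryl on the amide nitrogen were only modest, so nothing here points to a large move. For compound 4 a step of about a 1.0-fold lower number from compound 3 to compound 4 (0.00 log units; within the scatter) is expected, in no firm direction. Compound 4 is estimated at 40000 nM, between 12000 nM and 130000 nM.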

Compound 4, half-maximal inhibitory concentration: > 50000 nM
Compound 4 ended at the assay's limit; the forecaster's own chance of this, stated with the estimate: 10%; middle value at least 1.2-fold (0.09 log units) away from the limit.
By their numbers in this assay, from the lowest: compounds 2 and 1 (each within the scatter of the next); then compound 3. At a limit, above all of these: compound 4.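

Compound 4 reads only as a limit in this assay, not as a number: the limit of > 50000 nM in this assay, at which 1 of the 4 values shown sits. With nitro in place of chloro, the result is an at least 1.2-fold higher number from compound 3 to compound 4 (0.09 log units; that floor lies within the scatter), a floor that does not separate compound 4 from compound 3 but shows that the change brought no drop in the number. Exchanging the whole aryl on the amide nitrogen gives an at least 5.0-fold higher number from compound 2 to compound 4 (0.69 log units; beyond the scatter) and an at least 3.1-fold higher number from compound 1 to compound 4 (0.50 log units; beyond the scatter), so 4-nitrophenyl, like 4-chlorophenyl, stays on the weaker side of the 3-methoxyphenyl and 3-ethylphenyl compounds.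

Going by these compounds, how far compound 4 lies past its limit stays open, and with it the true size of the step from chloro to nitro. Also open, on these data alone, is whether an amine or a carboxylic acid in that place, or a 3-nitrophenyl on the amide nitrogen, would bring the number down.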